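Varying the aryl ester on a shared core

The source may report more compounds than this note shows. Statements on the series, on what has been measured and on what is new or still open speak of the compounds shown alone.

In a functional assay, read by spectrophotometry, with a stated time of 30 min (a higher number here means that more compound is needed for the effect, a lower number that less compound is needed), compound 1 `COc1cc(C2Oc3cc([C@H]4Oc5cc(O)cc(O)c5C(=O)[C@@H]4O)ccc3OC2COC(=O)c2ccc(N)cc2)ccc1O` gives 128000 nM, the highest of the three numbers measured, though both other compounds sit within the scatter of it. Compound 2 `COc1cc(C2Oc3cc([C@H]4Oc5cc(O)cc(O)c5C(=O)[C@@H]4O)ccc3OC2COC(=O)c2ccccc2)ccc1O` gives 105000 nM, and compound 3 `COc1cc(C2Oc3cc([C@H]4Oc5cc(O)cc(O)c5C(=O)[C@@H]4O)ccc3OC2COC(=O)c2cccc(Cl)c2)ccc1O` gives 106000 nM. Compound 4 `COc1cc(C2Oc3cc([C@H]4Oc5cc(O)cc(O)c5C(=O)[C@@H]4O)ccc3OC2COC(=O)c2cc([N+](=O)[O-])cc([N+](=O)[O-])c2)ccc1O` differs from compound 1 by 3,5-dinitrophenyl in place of 4-aminophenyl on a carbonyl carbon. Three measured steps alter this same aryl ester group: a 1.2-fold lower number from compound 1 to compound 2 (0.09 log units; within the scatter), a 1.2-fold lower number from compound 1 to compound 3 (0.08 log units; within the scatter) and a 1.0-fold higher number from compound 2 to compound 3 (0.00 log units; within the scatter), each within the scatter. Since changing what sits on this ring has so far moved nothing beyond the scatter, no step beyond the scatter is expected for the 3,5-dinitrophenyl group either. Compound 4 is therefore estimated at 110000 nM, with a range from 50000 nM to 250000 nM, meaning an expected step of a 1.2-fold lower number from compound 1 to compound 4 (0.07 log units; within the scatter).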

Compound 4, half-maximal effective concentration: 205000 nM
Compound 4: the middle estimate sits 1.9-fold (0.27 log units) below what was measured, within the range that was stated.
By their numbers in this assay, from the lowest: compounds 2, 3, 1 and 4 (each within the scatter of the next).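

The 3,5-dinitrophenyl group has more heavy atoms than the 4-aminophenyl group and no hydrogen-bond donors, yet each step to it stays within the scatter (a 1.6-fold higher number from compound 1 to compound 4 (0.20 log units; within the scatter)) and (a 1.9-fold higher number from compound 3 to compound 4 (0.29 log units; within the scatter)) and (a 2.0-fold higher number from compound 2 to compound 4 (0.29 log units; within the scatter)). Across these four aryl esters, then, no step at this position lies beyond the scatter. Nothing available explains this result.

Still open, from the compounds shown here alone, is whether a carboxylic acid or a longer chain in place of the aryl ring would also stay within the scatter. Changes to the shared core are also an open question.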